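Dropping the chloro group: expected effect on cytotoxicity

The source may report more compounds than this note shows. Statements on the series, on what has been measured and on what is new or still open speak of the compounds shown alone.

Measured compounds:
Compound 1 `Cc1ccc2c(Oc3ccccc3OCCn3ccc(=O)[nH]c3=O)cccc2c1`: 40000 nM
Compound 2 `N#Cc1ccc2c(Oc3ccc(Cl)cc3OCCn3ccc(=O)[nH]c3=O)cccc2c1`: > 100000 nM
Compound 3 `N#Cc1ccc2c(Oc3ccccc3OCCn3ccc(=O)[nH]c3=O)cc(Cl)cc2c1`: 24000 nM

The three compounds were tested in an ADME assay on MT2 cells (Homo sapiens) for cytotoxicity, read by MTT assay; on this read-out higher numbers stand for lower toxicity in this test and lower numbers for higher toxicity in this test. Compound 1 gives 40000 nM. For compound 2 the assay reports only a limit, > 100000 nM, rather than a number; this corresponds to the limit of > 100000 nM in this assay, at which 1 of the 3 values shown sits. Compound 3 gives 24000 nM. Among the two actual numbers, compound 3 and compound 1 sit within the usual scatter of each other, so no order can be read between them, and the third value is a limit.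

Compound 4 `N#Cc1ccc2c(Oc3ccccc3OCCn3ccc(=O)[nH]c3=O)cccc2c1` has not yet been measured in this assay. It differs from compound 3 in one place: hydrogen in place of chloro on an aromatic carbon. For the measured compounds named here, no pair of measured compounds here differs by exactly this change, so no measured step for it exists.

Given that compound 3 gives 24000 nM and that the only other number, from compound 1, lies within the scatter of it, the step from compound 3 to compound 4 is expected to be small, most likely no larger than the scatter, with a slight lean toward a higher number, estimated as a 1.5-fold higher number from compound 3 to compound 4 (0.16 log units; within the scatter). Compound 4 is therefore expected to give about 35000 nM, within a range from 14000 nM to 90000 nM.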

Compound 4, half-maximal cytotoxic concentration: > 100000 nM
Compound 4: a limit, no number; the forecaster's own chance of this, stated with the estimate: 20%; middle value at least 2.8-fold (0.45 log units) from the limit.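

Hydrogen in place of chloro at this aromatic carbon, para to a fused ring, gives an at least 4.1-fold higher number from compound 3 to compound 4 (0.61 log units; beyond the scatter) in this assay, so at this position the chloro group goes with the lower number, which stands for higher toxicity in this test. For the compounds shown here, the change of cyano in place of methyl, which no earlier pair isolated, gives an at least 2.5-fold higher number from compound 1 to compound 4 (0.39 log units; beyond the scatter) on the same shared core, so the group at that second place also counts for the read-out, and a methyl group there goes with the lower number. Compound 4 reports only a limit of the assay and not a number, the same limit as compound 2: the limit of > 100000 nM in this assay, at which 2 of the 4 values shown sit.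

On these data alone, the step between compound 2 and compound 4 cannot be read, as both values are limits, and the full size of the two readable steps stays open, since each gives only a lower bound. Also open, as far as these compounds go, is whether a fluoro group, a methoxy group or an amine at this aromatic carbon would go with the higher number seen with hydrogen or the lower one seen with chloro.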